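The compounds below may be only part of what the source reports. "The series", "measured", "known", "first", "only" and "open" are said of these compounds alone.

Compound 1, `C=CCCC(=O)N[C@H]1[C@@H](OCCc2ccccc2)O[C@H](CO)[C@@H](O)[C@@H]1O`, gives > 50 uM in a functional assay on A-375 cells (Homo sapiens), read by thymidine incorporation (on this read-out higher numbers stand for weaker inhibition and lower numbers for stronger inhibition), and that figure is a limit of this assay rather than a number. Compound 2, `CCCCCCCC/C=C\CCCCCCCCO[C@H]1O[C@H](CO)[C@@H](O)[C@H](O)[C@H]1NC(C)=O`, gives 4.8 uM in this assay. Compound 3, `CCCCCCCC/C=C\CCCCCCCCO[C@H]1O[C@H](CO)[C@@H](O)[C@H](OS(=O)(=O)O)[C@H]1NC(C)=O`, gives 2.1 uM in this assay.

Compound 1 and compound 2 are built on different cores, and the difference between the two cores is not broken down here. Compound 2 and compound 3 share a core and differ in one place: sulfo in place of hydrogen on an oxygen on a saturated carbon. That change gives a 2.3-fold lower number from compound 2 to compound 3 (0.36 log units; beyond the scatter) in this assay.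

Compound 4, `C=CCCC(=O)N[C@H]1[C@@H](OCCc2ccccc2)O[C@H](COS(=O)(=O)O)[C@@H](O)[C@@H]1O`, has not been measured. It differs from compound 1 in this way: sulfo in place of hydrogen on an oxygen on a saturated carbon. Going by the values given here, the change is the same kind of change as the one from compound 2 to compound 3, but not the same: in compound 3 the oxygen carrying the sulfo group sits on a saturated carbon whose other neighbour is a saturated ring carbon, whereas in compound 4 that carbon's other neighbour is a saturated chain carbon. For compound 4 a step of about an at least 1.1-fold lower number from compound 1 to compound 4 (0.04 log units; that floor lies within the scatter) is expected, resting on the step from compound 2 to compound 3 of a 2.3-fold lower number from compound 2 to compound 3 (0.36 log units; beyond the scatter) and on the fact that compound 1 sits at the limit of > 50 uM in this assay, at which 1 of the 3 values shown sits, so its true value is not known and the reported result for compound 4 may again be only a limit. Compound 4 is therefore estimated at 45 uM in this assay, expected to fall between 15 uM and 150 uM.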

Compound 4, concentration for 50% inhibition: > 50 uM
Compound 4: a limit, no number (the forecaster's own chance of this, stated with the estimate: 60%); at least 1.1-fold (0.04 log units) between middle value and limit.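

In this assay compound 4 gives > 50 uM and that figure is a limit, not a number. Compound 1 gives > 50 uM which is likewise a limit. Going by these compounds alone, no step from compound 1 to compound 4 can be read, because both results sit at the limit: the limit of > 50 uM in this assay, at which 2 of the 4 values shown sit. The compounds shown leave open whether sulfo in place of hydrogen at this oxygen changes the inhibition at all on the core of compound 1.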